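The source may report more compounds than this note shows. Statements on the series, on what has been measured and on what is new or still open speak of the compounds shown alone.

Working notes on the series. In a functional assay on MV4-11 cells (Homo sapiens) for inhibition, read by resazurin assay, with a stated time of 72 h (on this read-out higher numbers stand for weaker inhibition of growth and lower numbers for stronger inhibition of growth), compound 1 `Cc1ccc(-c2cncc(Cl)c2N2CCC3(CCNC3=O)CC2)o1` gives 4950 nM, compound 2 `O=Cc1ccc(-c2cncc(Cl)c2N2CCC3(CCNC3=O)CC2)o1` gives 5190 nM and compound 3 `CCOCOCc1ccc(-c2cncc(Cl)c2N2CCC3(CCNC3=O)CC2)o1` gives 2970 nM. Compound 2 therefore stands within the scatter of both neighbours, and the three values do not separate.

The next change keeps the formyl group and the rest of compound 2 and alters only the five-membered aromatic ring, giving compound 4 `O=Cc1ccc(-c2cncc(Cl)c2N2CCC3(CCNC3=O)CC2)s1`: 5-formylthiophen-2-yl in place of 5-formylfuran-2-yl on an aromatic carbon. The 5-formylthiophen-2-yl group takes the place of 5-formylfuran-2-yl on an aromatic carbon of a six-membered aromatic ring with 1 nitrogen.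

For the measured compounds named here, no measured pair varies that ring itself, so the evidence is indirect. The nearest guide is the substituent on the same ring, where the change of methyl to formyl gave a 1.0-fold higher number from compound 1 to compound 2 (0.02 log units; within the scatter) and the change of formyl to (ethoxymethoxy)methyl gave a 1.7-fold lower number from compound 2 to compound 3 (0.24 log units; within the scatter). The remaining pair gave a 1.7-fold lower number from compound 1 to compound 3 (0.22 log units; within the scatter). All three steps stay within the scatter, so this part of the molecule has so far tolerated change, though only across these three compounds.

On that basis, no shift beyond the scatter is expected, and the expected step is a 1.2-fold lower number from compound 2 to compound 4 (0.06 log units; within the scatter). The estimate for compound 4 is 4500 nM, with an expected range of 1800 nM to 11000 nM.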

Compound 4, concentration for 50% growth inhibition: 750 nM
Compound 4: middle estimate off by 6.0-fold (0.78 log units), on the high side; measured number outside the range, below it.
By their numbers in this assay, from the lowest: compound 4; then compounds 3, 1 and 2 (each within the scatter of the next).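

In this assay, for the compounds shown here, 5-formylthiophen-2-yl in place of 5-formylfuran-2-yl gives a 6.9-fold lower number from compound 2 to compound 4 (0.84 log units; beyond the scatter), the first step to lie beyond the scatter, so this position, on an aromatic carbon two atoms from the ring nitrogen, responds to the five-membered aromatic ring itself, whereas the changes of substituent among compounds 1, 2 and 3 left the values unseparated. The second new step, a 6.6-fold lower number from compound 1 to compound 4 (0.82 log units; beyond the scatter), points the same way, but it changes the ring and the substituent together and cannot be assigned to either one alone. The two groups differ by one sulfur for one oxygen, with the same counts of heavy atoms, hydrogen-bond donors and hydrogen-bond acceptors, and nothing measured here accounts for the difference in growth inhibition.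

On these data alone, it remains open whether the thiophene ring keeps this advantage when the formyl group gives way to methyl or (ethoxymethoxy)methyl, or to an amine or a carboxylic acid. Also open, as far as these compounds go, is how other aromatic rings, such as a thiazole or a phenyl ring, would compare at the same position.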